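The source may report more compounds than this note shows. Statements on the series, on what has been measured and on what is new or still open speak of the compounds shown alone.

Measured compounds in this series:

Compound 1 `CC/N=C(/NC#N)NCCCn1nc(-c2ccccc2)cc(C)c1=O` gives 23.5% in a functional assay on the whole organism with Rattus norvegicus as the target, at a dose of 100 mg/kg; a higher number here means more inhibition at the dose given (going by the name of the read-out), a lower number less inhibition.
Compound 2 `CC/N=C(/NC#N)NCCCn1nc(-c2ccccc2)ccc1=O` gives 62.9% in this assay.
Compound 3 `C/N=C(\S)NCCCCCCn1nc(-c2ccccc2)ccc1=O` gives 22.2% in this assay.

Compound 2 stands highest of the three numbers; the nearest is compound 1, the furthest compound 3, and both gaps are beyond the scatter. The step of a number 39.4 percentage points higher from compound 1 to compound 2 (beyond the scatter) went with hydrogen in place of methyl on an aromatic carbon, and the step of a number 40.7 percentage points lower from compound 2 to compound 3 (beyond the scatter) went with an exchange of the chain end, which does not bear on the present change.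

Compound 4 `CC/N=C(/NC#N)NCCCn1nc(-c2ccccc2)c(C)cc1=O` differs from compound 2 by methyl in place of hydrogen on an aromatic carbon. The methyl enters ortho to a phenyl group, two atoms from the ring nitrogen, so it is not a simple reversal of the step from compound 1 to compound 2, where the methyl sat at another carbon of the same ring. Still, that step is the only one on a methyl at this ring and it was large, so a loss in this assay is the expectation. The place differs, and the expected loss is set smaller than the one seen there. Compound 4 is therefore estimated at 40%, within 15% to 65%, an expected step of a number 22.9 percentage points lower from compound 2 to compound 4 (beyond the scatter).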

Compound 4, a percentage reported as inhibition, in the whole organism at one dose (the size of the read-out at that dose, not a potency): 0.2%
For compound 4 the middle estimate is 39.8 percentage points above the measured one, outside the stated range (below it).
By their numbers in this assay, from the lowest: compound 4; then compounds 3 and 1 (each within the scatter of the next); then compound 2.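

Methyl in place of hydrogen on the aromatic carbon ortho to a phenyl group goes with a number 62.7 percentage points lower from compound 2 to compound 4 (beyond the scatter) in this assay, and compound 4 gives 0.2%, so almost nothing of the inhibition at this dose remains. Alongside a number 39.4 percentage points higher from compound 1 to compound 2 (beyond the scatter), this makes two carbons of the same ring where a methyl goes with a number lower than that of compound 2, which holds hydrogen at both; the pattern rests on these three compounds alone, and compound 1 at 23.5% keeps a measurable read-out where compound 4 does not. No measurement on hand explains the loss at either carbon.

The compounds shown leave open whether the loss at this position is particular to methyl, or whether a fluorine atom, a chlorine atom, an ethyl or a methoxy group on the same carbon would go with a comparable number. They also leave open whether the same methyl would cost as much with the longer chain and the other chain end of compound 3, and, with one dose in one whole-organism read-out, how far the numbers of compound 2 and compound 4 would hold at other doses.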